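Swapping the side-chain ring in a stable series

A few compounds are considered here, and "the series" means these few. Any claim that something is new, unique, unknown or untested is made for them only; others in the source may bear on it.

Compound 1 `COc1cccc(CCOc2ccc(-c3c(C)nc(C)c([C@H](OC(C)(C)C)C(=O)O)c3N3CCC(C)(C)CC3)cc2)c1` carries a 3-methoxyphenyl group on its side chain. In an ADME assay on microsomes from liver (Rattus norvegicus) for metabolic stability, read by LC-MS, tested at 0.5 uM (a lower number here means that the compound disappears faster, a higher number that the compound lasts longer), compound 1 gives > 2 h, a limit of the assay rather than a number. Compound 2 `Cc1nc(C)c([C@H](OC(C)(C)C)C(=O)O)c(N2CCC(C)(C)CC2)c1-c1ccc(OCCc2ccc(F)cc2F)cc1` gives > 2 h in this assay, again only a limit. Compound 3 `Cc1ccc(CCOc2ccc(-c3c(C)nc(C)c([C@H](OC(C)(C)C)C(=O)O)c3N3CCC(C)(C)CC3)cc2)s1` likewise gives > 2 h, also a limit. The steps between them, a step that the two limits leave unreadable from compound 1 to compound 2, a step that the two limits leave unreadable from compound 1 to compound 3 and a step that the two limits leave unreadable from compound 2 to compound 3, therefore show no readable size, because of the limit of > 2 h in this assay, at which 3 of the 3 values shown sit. Compound 4 `Cc1ncsc1CCOc1ccc(-c2c(C)nc(C)c([C@H](OC(C)(C)C)C(=O)O)c2N2CCC(C)(C)CC2)cc1` differs from compound 1 in one place: 4-methyl-1,3-thiazol-5-yl in place of 3-methoxyphenyl on a saturated chain carbon, two bonds along the chain from an oxygen on an aromatic ring. With every measured side-chain ring reaching the limit, compound 4 is expected to last long as well. Its half-life in this assay is estimated at 2.5 h, between 1.2 h and 5 h, so the step that the limit leaves unreadable from compound 1 to compound 4 is expected to be small.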

Compound 4, half-life: > 2 h
Compound 4: no number, only a limit; the forecaster's own chance of this, stated with the estimate: 75%; the middle value lies beyond the limit too.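

Compound 4 gives > 2 h, which is a limit and not a number, so its steps from compound 1, compound 2 and compound 3 cannot be read, because: the limit of > 2 h in this assay, at which 4 of the 4 values shown sit.

Going by these compounds, how long these four compounds actually last in this assay, and whether their side-chain rings make any difference, stays open.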